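Alkyl chain lengthening and growth inhibition: compound 4

The compounds below may be only part of what the source reports. "The series", "measured", "known", "first", "only" and "open" are said of these compounds alone.

Three compounds have numbers in a functional assay on HBL-100 cells (Homo sapiens) for antiproliferative activity, read by sulforhodamine B assay, with a stated time of 48 h; a lower number here means a stronger inhibitor of growth, a higher number a weaker inhibitor of growth. Compound 1 `COC(=O)C#CC(CC(C)C)O/C=C/C(=O)OC` gives 330 nM. Compound 2 `CC(C)C(C#CC(=O)OC(C)(C)C)O/C=C/C(=O)OC(C)(C)C` gives 3000 nM. Compound 3 `CCCCCC(C#CC(=O)OC)O/C=C/C(=O)OC` gives 1900 nM, the second highest of the three numbers; compound 2 lies within the scatter of it, while compound 1 lies beyond the scatter below it, the step being a 5.8-fold higher number from compound 1 to compound 3 (0.76 log units; beyond the scatter).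

Compound 4 `CCCCCCC(C#CC(=O)OC)O/C=C/C(=O)OC` differs from compound 3 by methyl in place of hydrogen on a saturated chain carbon, six bonds along the chain from an oxygen on an unsaturated carbon and a triple-bonded carbon. Read one bond further out, the same difference is propyl to butyl, so it continues the lengthening of the saturated chain at that place.

Within the data shown here, only one measured step bears on it: a 5.8-fold higher number from compound 1 to compound 3 (0.76 log units; beyond the scatter), where butyl in place of isopropyl went with a higher number, a modest step beyond the scatter. Among the measured compounds shown here, that change is of a different kind from adding a methyl to an already unbranched chain, so it is a weak guide, and no pair among the three measured compounds isolates a single methyl. The expectation for compound 4 is a small further rise in this assay, or none beyond the scatter, as a step of a 1.3-fold higher number from compound 3 to compound 4 (0.12 log units; within the scatter). Compound 4 is therefore estimated at 2500 nM in this assay, with a range from 1200 nM to 5500 nM.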

Compound 4, concentration for 50% growth inhibition: 2500 nM
For compound 4 middle estimate and measured number coincide at the digits printed; measured number inside the range.
By their numbers in this assay, from the lowest: compound 1; then compounds 3, 4 and 2 (each within the scatter of the next).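

In this assay, among these compounds, the step of a 1.3-fold higher number from compound 3 to compound 4 (0.12 log units; within the scatter) is the first that isolates a single methyl on the unbranched chain, and it lies within the scatter, so butyl and pentyl at this place are not told apart by this read-out. The isopropyl end of compound 1 now stands apart from two unbranched chains rather than one: the step of a 7.6-fold higher number from compound 1 to compound 4 (0.88 log units; beyond the scatter) is beyond the scatter, as was a 5.8-fold higher number from compound 1 to compound 3 (0.76 log units; beyond the scatter), so the separation does not rest on compound 3 alone. No evidence on the cause of either step is available.

Going by these compounds, whether a longer chain such as hexyl or octyl at this place would remain within the scatter of compound 4, or whether a chain ending in an amine or a carboxylic acid would shift the number, remains open. The compounds shown also do not tell whether the lower number of compound 1 is particular to its isopropyl end or would be shared by a tert-butyl or cyclohexyl end.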